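The compounds below may be only part of what the source reports. "The series", "measured", "known", "first", "only" and "open" are said of these compounds alone.

Compound 1, `Cc1ccc2[nH]c(-n3[nH]c(C)c(Cc4ccccc4)c3=O)nc2c1`: 670 nM
Compound 2, `COC(=O)Cc1c(C)[nH]n(-c2nc3ccccc3[nH]2)c1=O`: 4300 nM

Of the compounds shown here, two have been measured so far. In an assay on isolated protein for inhibition of alpha-ketoglutarate-dependent dioxygenase alkB homolog 3 (Homo sapiens), read by polymerase chain reaction, with a stated time of 1 h (a lower number here means a stronger inhibitor, a higher number a weaker inhibitor), compound 1 gives 670 nM, while compound 2 gives 4300 nM. Compound 2 therefore stands at the highest of the two numbers, and the gap to compound 1 lies beyond the usual scatter of the measurement; since the two structures differ in more than one place, nothing more than the two values themselves can be read from that gap.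

The next compound, compound 3, `Cc1[nH]n(-c2nc3ccccc3[nH]2)c(=O)c1CC(=O)O`, is derived from compound 2 by a single alteration: hydrogen in place of methyl on an oxygen next to a carbonyl group. Among the measured compounds shown here, no measured pair in the present set shows this same change, so there is no step to lean on. The expectation is that the step from this change in this assay, a 1.1-fold lower number from compound 2 to compound 3 (0.03 log units; within the scatter), stays within the scatter, with no firm direction. On that basis compound 3 is estimated at 4000 nM in this assay, with a range from 1200 nM to 14000 nM.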

Compound 3, half-maximal inhibitory concentration: 15000 nM
For compound 3 the middle estimate is 3.8-fold (0.57 log units) below the measured one; measured number above the stated range.
By their numbers in this assay, from the lowest: compound 1; then compound 2; then compound 3.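

In this assay, the change from methoxy to hydroxy, which turns (methoxycarbonyl)methyl into carboxymethyl, gives a 3.5-fold higher number from compound 2 to compound 3 (0.54 log units; beyond the scatter), so the inhibitor becomes weaker. Among the compounds shown here, this is the first difference in one place that can be read, and it shows that the methyl on this oxygen is not a silent part of the structure: removing that single heavy atom moves the number beyond the scatter. No measured evidence is available to explain why this step goes in this direction or has this size.

The pair cannot separate the effect of losing this particular methyl from that of having a carboxy group in its place, and an ethyl ester, a primary amide or a longer chain ending in the same carboxy group would each test a different part of that question. On these data alone, it also remains open whether the step would carry over to the core of compound 1, which differs from compound 2 in more than one place and so offers no direct comparison.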